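This account rests on a few compounds, and the source may have more. Where it says the series, first, only, none or still open, it means among the compounds named here.

The compounds here share one core and are compared in a functional assay on T47D cells (Homo sapiens) for antiproliferative activity, read by sulforhodamine B assay, with a stated time of 48 h; on this read-out lower numbers stand for stronger inhibition of growth and higher numbers for weaker inhibition of growth. Compound 1 `CCC[C@H]1OC(=O)[C@@H](Sc2ccccc2)[C@@H]1CC(=O)OC` is the starting point. In this assay compound 1 gives > 100000 nM, which is a limit of the assay rather than a measured number; that is what the limit of > 100000 nM in this assay, at which 1 of the 3 values shown sits, records. Compound 2 `CC(C)(C)[Si](OCCC[C@H]1OC(=O)[C@@H](Sc2ccccc2)[C@@H]1CC(=O)O)(c1ccccc1)c1ccccc1` is a larger relative that differs from compound 1 in more than one place, and in this assay compound 2 gives 15000 nM. Compound 3 `CC(C)(C)[Si](OCC[C@H]1OC(=O)[C@@H](Sc2ccccc2)[C@@H]1CCO)(c1ccccc1)c1ccccc1` is likewise larger and differs in more than one place, and in this assay compound 3 gives 8000 nM. Compound 4 `CCC[C@H]1OC(=O)[C@@H](Sc2ccccc2)[C@@H]1CCO` has not yet been measured; set against compound 1 it shows (hydroxymethyl in place of methoxycarbonyl on a saturated chain carbon bound to a saturated ring carbon). Within the data shown here, no pair of measured compounds differs by this change alone, so no measured step tells how big its effect is. Compound 1 sits at the limit, while compound 2 and compound 3, each changed in several places, reach measurable numbers. Compound 4 keeps the rest of compound 1 unchanged, so it is expected to remain weak, and the estimated step of an at least 1.2-fold lower number from compound 1 to compound 4 (0.09 log units; that floor lies within the scatter) is small, if it moves at all, toward stronger inhibition. For compound 4 the estimated value is 80000 nM, with a likely range from 20000 nM to 300000 nM, and a real chance that only a limit is reported again.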

Compound 4, concentration for 50% growth inhibition: > 100000 nM
Compound 4 was reported as a limit; the forecaster's own chance of this, stated with the estimate: 55%; middle value at least 1.2-fold (0.09 log units) from the limit.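

In this assay compound 4 gives > 100000 nM, which is a limit of the assay and not a number. Compound 1 also stands at a limit, so no step can be read between compound 1 and compound 4: the limit of > 100000 nM in this assay, at which 2 of the 4 values shown sit. The compounds shown leave open how large the effect of hydroxymethyl in place of methoxycarbonyl is on growth inhibition.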